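Compound 1 to compound 4: diethylamino for pyrrolidin-1-yl

A few compounds are considered here, and "the series" means these few. Any claim that something is new, unique, unknown or untested is made for them only; others in the source may bear on it.

Compound 1 (`CC(=O)c1ccc(-c2ccc(N3CCCC3)nn2)cc1`) is the starting point in a functional assay on NCI-H727 cells (Homo sapiens) for antiproliferative activity, with a stated time of 48 h; on this read-out higher numbers stand for weaker inhibition and lower numbers for stronger inhibition. There compound 1 gives > 25000 nM, which is a limit and not a number. Compound 2 (`CCN(CC)c1ccc(-c2cccc(C(F)(F)F)c2)nn1`), which carries diethylamino, gives > 25000 nM, likewise a limit. The evidence so far is the limit of > 25000 nM in this assay, at which 3 of the 3 values shown sit, so compound 1 cannot be ranked against the others.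

Compound 4 (`CCN(CC)c1ccc(-c2ccc(C(C)=O)cc2)nn1`) keeps the rest of compound 1 and changes one group: diethylamino in place of pyrrolidin-1-yl on an aromatic carbon. Diethylamino thus replaces pyrrolidin-1-yl on an aromatic carbon.

For the measured compounds named here, the only measured step is a step that the two limits leave unreadable from compound 2 to compound 3. It leaves the amino group untouched and gives no size to carry over. Compound 3 (`CCN(CC)c1ccc(-c2cccc(C#N)c2)nn1`), with the same diethylamino, gives > 25000 nM, again a limit, so no step beyond the scatter is expected for this exchange, in either direction.

The expected outcome in this assay is a step that the limit leaves unreadable from compound 1 to compound 4. Compound 4 is estimated as 30000 nM, with an expected range of 15000 nM to 60000 nM.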

Compound 4, half-maximal inhibitory concentration: 25000 nM
Compound 4: middle estimate off by 1.2-fold (0.08 log units), on the high side; low and high end bracket the measured number.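

In this assay, diethylamino in place of pyrrolidin-1-yl gives a number no higher from compound 1 to compound 4 (the limit leaves the size open). For the compounds shown here, compound 4 gives 25000 nM, the first value that is a number and not a limit, so this position, on the core of compound 1, can carry an open-chain amino group and still give a readable value. The exchange opens no clear window on activity, as most of the series still sits at the limit: the limit of > 25000 nM in this assay, at which 3 of the 4 values shown sit.

The size of the step stays unreadable, and the compounds shown do not tell whether the ring itself matters at this position. On these data alone, it remains open whether morpholin-4-yl, piperidin-1-yl or a longer chain on the amine nitrogen would move the read-out beyond the scatter.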